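A few compounds are considered here, and "the series" means these few. Any claim that something is new, unique, unknown or untested is made for them only; others in the source may bear on it.

Of the compounds shown here, two have been measured in a functional assay on MIA PaCa-2 cells (Homo sapiens) for inhibition, read by MTT assay, with a stated time of 3 days; on this read-out lower numbers stand for stronger inhibition and higher numbers for weaker inhibition. Compound 1, `CCN(CC)S(=O)(=O)c1ccc(S(=O)(=O)N2CCC[C@@H](C(=O)N[C@H]3CC[C@H](OC)CC3)C2)cc1`, gives 2290 nM, the highest of the two numbers and therefore the weaker inhibitor of the pair. Compound 2, `CC(C)S(=O)(=O)c1ccc(S(=O)(=O)N2CCC[C@@H](C(=O)N3CCC(F)(F)CC3)C2)cc1`, gives 9.1 nM, a far lower number that stands well beyond the scatter, although it differs from compound 1 in more than one place, so no single change can be credited. Compound 3, `CCN(CC)S(=O)(=O)c1ccc(S(=O)(=O)N2CCC[C@@H](C(=O)N3CCOCC3)C2)cc1`, has not been measured. It differs from compound 1 in one place: morpholin-4-yl in place of (4-methoxycyclohexyl)amino on a carbonyl carbon. Compound 2 also carries a ring nitrogen directly on its carbonyl carbon, and its value in this assay is the lower one, so compound 3 is expected to move in the same direction, though by a smaller and uncertain amount. The step from compound 1 to compound 3 is estimated as a 5.7-fold lower number from compound 1 to compound 3 (0.76 log units; beyond the scatter). For compound 3 the estimate is 400 nM, with a range from 60 nM to 2500 nM.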

Compound 3, half-maximal inhibitory concentration: 160 nM
For compound 3 the middle estimate is 2.5-fold (0.40 log units) above the measured one, and the stated range covers the measured number.
By their numbers in this assay, from the lowest: compound 2; then compound 3; then compound 1.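

In this assay, the first change made in one place alone gives a 14-fold lower number from compound 1 to compound 3 (1.16 log units; beyond the scatter), so the group on this carbonyl carbon strongly affects the read-out while the rest of compound 1 stays the same. The swap alters several things at once: morpholin-4-yl has fewer heavy atoms than (4-methoxycyclohexyl)amino, has no hydrogen-bond donor, has no defined stereocentres and carries its oxygen within the ring. No available measurement shows which of these differences matters, or why the number falls.

It remains open which of these features accounts for the step. Placing a piperidin-1-yl or a dimethylamino group on the same carbonyl carbon of compound 1 would help to separate the role of the ring oxygen from that of the amide hydrogen.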